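Piperidinyl to methylpiperazinyl on the chain of compound 2

The source may hold more compounds than are shown below. What is called first, only, known or untested is meant among the compounds shown, and "the series" means these compounds.

Measured in a functional assay on the whole organism with Mus musculus as the target, in the rotarod test; on this read-out lower numbers stand for an effect already at smaller amounts and higher numbers for an effect only at larger amounts of compound:
- compound 1 (`CC(=O)NCC(=O)Nc1ccc(Cl)cc1C(=O)c1ccccc1`): > 100 mg/kg (a limit)
- compound 2 (`CN(C(=O)CNC(=O)CN1CCCCC1)c1ccc(Cl)cc1C(=O)c1ccccc1Cl`): > 100 mg/kg (a limit)
- compound 3 (`CN(C(=O)CNC(=O)CN)c1ccc([N+](=O)[O-])cc1C(=O)c1ccccc1Cl`): 10 mg/kg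

Compound 2 stands at > 100 mg/kg, which is a limit of the assay and not a number. The same ceiling recurs in the small set, as the limit of > 100 mg/kg in this assay, at which 2 of the 3 values shown sit, shows. Only compound 3 gives a number, 10 mg/kg.

Compound 4 (`CN1CCN(CC(=O)NCC(=O)N(C)c2ccc(Cl)cc2C(=O)c2ccccc2Cl)CC1`) keeps the frame of compound 2 and carries 4-methylpiperazin-1-yl in place of piperidin-1-yl on a saturated chain carbon bound to a carbonyl carbon. Going by the values given here, no measured pair differs in one place only, so nothing measured sizes this change. No shift beyond the scatter is expected in this assay, and a report of the limit alone is the likeliest outcome. The expected step is a number no higher from compound 2 to compound 4 (the limit leaves the size open). For compound 4 the estimated value is 100 mg/kg. The expected range for compound 4 runs from 40 mg/kg to 200 mg/kg.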

Compound 4, dose for half-maximal effect: > 100 mg/kg
Compound 4: a limit, no number; the forecaster's own chance of this, stated with the estimate: 70%; the middle value sits exactly at the limit.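

No step can be read from compound 2 to compound 4 in this assay, as both are reported only as a limit: the limit of > 100 mg/kg in this assay, at which 3 of the 4 values shown sit.

The compounds shown leave open whether 4-methylpiperazin-1-yl in place of piperidin-1-yl on a saturated chain carbon bound to a carbonyl carbon shifts this read-out at all.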